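Working notes: from compound 3 to compound 4

A few compounds are considered here, and "the series" means these few. Any claim that something is new, unique, unknown or untested is made for them only; others in the source may bear on it.

Values in a functional assay on HT-29 cells (Homo sapiens) for cytotoxicity, read by MTT assay; a higher number here means a weaker inhibitor, a lower number a stronger inhibitor:
- compound 1 `COc1ccc(OC)c(C(=O)/C=C/c2ccc(C)s2)c1`: 1800 nM
- compound 2 `COc1ccc(OC)c(C(=O)/C=C/c2ccc(OC(=O)/C=C/c3ccc(C)cc3)cc2)c1`: 16400 nM
- compound 3 `COc1ccc(/C=C/C(=O)Oc2ccc(/C=C/C(=O)c3cc(OC)ccc3OC)cc2)cc1`: 23000 nM

Compound 3 lies within the scatter of compound 2, and its number is well above that of compound 1. Compound 4 `COc1ccc(OC)c(C(=O)/C=C/c2ccc(OC(=O)/C=C/c3cc(OC)c(OC)c(OC)c3)cc2)c1` differs from compound 3 at one place: 3,4,5-trimethoxyphenyl in place of 4-methoxyphenyl on a double-bonded chain carbon bound to a double-bonded chain carbon, on a double-bonded chain carbon bound to a double-bonded chain carbon. Within the data shown here, one measured step bears on this change: a 1.4-fold higher number from compound 2 to compound 3 (0.15 log units; within the scatter). It alters a substituent on the same aromatic ring, but it is a smaller change. No step beyond the scatter is therefore expected in this assay, and no direction is favoured. The expected step is a 1.2-fold lower number from compound 3 to compound 4 (0.06 log units; within the scatter). Compound 4 is estimated at 20000 nM, with an expected range from 7000 nM to 45000 nM.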

Compound 4, half-maximal inhibitory concentration: 23800 nM
For compound 4 the middle estimate is 1.2-fold (0.08 log units) below the measured one; low and high end bracket the measured number.
By their numbers in this assay, from the lowest: compound 1; then compounds 2, 3 and 4 (each within the scatter of the next).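

In this assay, 3,4,5-trimethoxyphenyl in place of 4-methoxyphenyl on a double-bonded chain carbon bound to a double-bonded chain carbon gives a 1.0-fold higher number from compound 3 to compound 4 (0.01 log units; within the scatter), so a larger substitution than the earlier methoxy-for-methyl swap still leaves the number within the scatter. With a 1.5-fold higher number from compound 2 to compound 4 (0.16 log units; within the scatter) as well, compounds 2, 3 and 4 cannot be told apart in this assay, although their aryl groups differ. No measurement at hand accounts for this result.

From the compounds shown here alone, whether an amine or a carboxylic acid on this aromatic ring would shift the number beyond the scatter remains open. Also open, going by these compounds, is whether the same holds with an amide in place of the ester linkage.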